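From a fluorophenyl arm to a phenylethenyl arm

The source may hold more compounds than are shown below. What is called first, only, known or untested is meant among the compounds shown, and "the series" means these compounds.

In a functional assay on HepG2 cells (Homo sapiens) for inhibition, read by MTT assay, with a stated time of 48 h (on this read-out higher numbers stand for weaker inhibition and lower numbers for stronger inhibition), compound 1 `O=C(CSc1nnc(-c2ccncc2)n1-c1ccccc1)N/N=C/c1ccc(Cl)cc1` gives 11000 nM. Compound 2 `O=C(CSc1nnc(-c2ccncc2)n1-c1ccccc1)N/N=C/c1cccc(F)c1` gives 24400 nM in this assay, the highest of the two numbers measured, the step being a 2.2-fold higher number from compound 1 to compound 2 (0.35 log units; beyond the scatter). Compound 3 `O=C(CSc1nnc(-c2ccncc2)n1-c1ccccc1)N/N=C/C=C/c1ccccc1` differs from compound 2 by 2-phenylethenyl in place of 3-fluorophenyl on a carbon with a double bond to nitrogen. For the measured compounds named here, no measured step covers this kind of change, and the only known step, a 2.2-fold higher number from compound 1 to compound 2 (0.35 log units; beyond the scatter), was modest, so nothing beyond the scatter is expected in this assay. Compound 3 is therefore estimated at 20000 nM, with a range from 8000 nM to 50000 nM. The step this estimate means is expected to be a 1.2-fold lower number from compound 2 to compound 3 (0.09 log units; within the scatter).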

Compound 3, half-maximal inhibitory concentration: 8280 nM
For compound 3 the middle estimate is 2.4-fold (0.38 log units) above the measured one, within the range that was stated.
By their numbers in this assay, from the lowest: compounds 3 and 1 (each within the scatter of the next); then compound 2.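

At this carbon with a double bond to nitrogen, 2-phenylethenyl in place of 3-fluorophenyl gives a 2.9-fold lower number from compound 2 to compound 3 (0.47 log units; beyond the scatter) in this assay, so the position accepts an arm with a double bond outside aromatic rings. Against the 4-chlorophenyl arm, the same arm gives a 1.3-fold lower number from compound 1 to compound 3 (0.12 log units; within the scatter), which leaves compound 1 and compound 3 indistinguishable here. No measured evidence accompanies these numbers to account for the steps. From the compounds shown here alone, whether an amine, a carboxylic acid or a longer chain at this place would move the number stays open.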